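Compound 4: a new aryl group on a flat series

The compounds below may be only part of what the source reports. "The series", "measured", "known", "first", "only" and "open" are said of these compounds alone.

In a functional assay on DU-145 cells (Homo sapiens) for inhibition, read by trypan blue exclusion, with a stated time of 96 h (a higher number here means a weaker inhibitor of growth, a lower number a stronger inhibitor of growth), compound 1 (`Cc1ccc(CS/C(=C/c2ccc(Br)cc2)C(=O)c2ccc(Cl)cc2)cc1`) gives 10000 nM and compound 2 (`COc1ccccc1/C=C(/SCc1ccc(C)cc1)C(=O)c1ccc(Cl)cc1`) gives 10000 nM while compound 3 (`Cc1ccc(CS/C(=C/c2cc(Cl)cc(Cl)c2)C(=O)c2ccc(Cl)cc2)cc1`) gives 10000 nM as well, so compound 3 stands level with the other two.

Compound 4 (`Cc1ccc(CS/C(=C/c2cc([N+](=O)[O-])ccc2F)C(=O)c2ccc(Cl)cc2)cc1`) carries 2-fluoro-5-nitrophenyl in place of 3,5-dichlorophenyl on a double-bonded chain carbon bound to a double-bonded chain carbon. The counted difference is 2-fluoro-5-nitrophenyl in place of 3,5-dichlorophenyl on a double-bonded chain carbon bound to a double-bonded chain carbon and the rest of the structure is shared.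

Within the data shown here, three measured steps bear on this change, since all of them swap the aryl group at that same place. They are no change at the digits printed from compound 1 to compound 2 (within the scatter) and no change at the digits printed from compound 1 to compound 3 (within the scatter) and no change at the digits printed from compound 2 to compound 3 (within the scatter) with none of them showing any size at all. None of them involves a fluoro or nitro group, so the data say nothing direct about the entering group, and a flat set of three is thin support.

The expected outcome is a 1.4-fold lower number from compound 3 to compound 4 (0.15 log units; within the scatter) in this assay with no direction expected beyond the scatter. Compound 4 is estimated at 7000 nM with an expected range from 1500 nM to 15000 nM in this test.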

Compound 4, concentration for 50% growth inhibition: 1000 nM
Compound 4: the middle estimate sits 7.0-fold (0.85 log units) above what was measured; the measured number lies below the stated range.
By their numbers in this assay, from the lowest: compound 4; then compounds 1, 2 and 3 (each within the scatter of the next).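

At this place, on a double-bonded chain carbon bound to a double-bonded chain carbon, the aryl group does matter in this assay and the earlier flat set gave no sign of this: the steps to the new group are a 10-fold lower number from compound 3 to compound 4 (1.00 log units; beyond the scatter) and a 10-fold lower number from compound 2 to compound 4 (1.00 log units; beyond the scatter) and a 10-fold lower number from compound 1 to compound 4 (1.00 log units; beyond the scatter) with all three beyond the scatter. Among the four compounds, 2-fluoro-5-nitrophenyl is the only aryl group that separates from the rest, while 4-bromophenyl, 2-methoxyphenyl and 3,5-dichlorophenyl remain level with one another, so the series is no longer flat at this place. No measurement in hand explains why this group gives the lower number.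

The entering group brings fluoro and nitro in a single change, so these compounds cannot show whether one of them alone accounts for the step or whether both are needed. Also open, going by these compounds, is how the series would read with an amine, a nitrile or a carboxylic acid on this aryl ring, and whether any such group would carry the number lower still.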